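The source may hold more compounds than are shown below. What is called first, only, known or untested is meant among the compounds shown, and "the series" means these compounds.

Three compounds built on one shared core were tested in a functional assay on HepG2 cells (Homo sapiens) for antiproliferative activity, read by MTT assay, with a stated time of 48 h; a lower number here means a stronger inhibitor, a higher number a weaker inhibitor. Compound 1 `Clc1cccc(Nc2ncnc3ccc(NCc4cccc(Br)n4)cc23)c1` gives 3870 nM, compound 2 `Clc1cccc(Nc2ncnc3ccc(NCc4ncc5ccccc5n4)cc23)c1` gives 5650 nM, and compound 3 `Clc1cccc(Nc2ncnc3ccc(NCc4cccs4)cc23)c1` gives 3580 nM. The three differ only in the aromatic group on a saturated chain carbon bound to a nitrogen on an aromatic ring, and every exchange of that group produced a step within the scatter: a 1.5-fold higher number from compound 1 to compound 2 (0.16 log units; within the scatter), a 1.1-fold lower number from compound 1 to compound 3 (0.03 log units; within the scatter), and a 1.6-fold lower number from compound 2 to compound 3 (0.20 log units; within the scatter). Compound 3 thus stands at the low end of the three numbers, yet the other two lie within the scatter of it, so none of the three can be singled out as the stronger inhibitor.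

Compound 4 `Clc1cccc(Nc2ncnc3ccc(NCc4c[nH]c5ccccc45)cc23)c1` extends this set with 1H-indol-3-yl in place of thiophen-2-yl on a saturated chain carbon bound to a nitrogen on an aromatic ring. All three measured steps bear on this change, since each replaced one aromatic group by another at the same place, and none of them moved beyond the scatter. The same outcome is expected here, so the step expected in this assay is a 1.1-fold higher number from compound 3 to compound 4 (0.05 log units; within the scatter), nothing beyond the scatter. The expected value for compound 4 is 4000 nM, with a range from 1500 nM to 11000 nM.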

Compound 4, half-maximal inhibitory concentration: 5260 nM
Compound 4: the middle estimate sits 1.3-fold (0.12 log units) below what was measured, and the stated range covers the measured number.
By their numbers in this assay, from the lowest: compounds 3, 1, 4 and 2 (each within the scatter of the next).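

In this assay, 1H-indol-3-yl brings a hydrogen-bond donor and a second aromatic ring to the place on a saturated chain carbon bound to a nitrogen on an aromatic ring, whereas thiophen-2-yl has no such donor, yet this exchange gives only a 1.5-fold higher number from compound 3 to compound 4 (0.17 log units; within the scatter). The exchanges from the other two groups give a 1.1-fold lower number from compound 2 to compound 4 (0.03 log units; within the scatter) and a 1.4-fold higher number from compound 1 to compound 4 (0.13 log units; within the scatter), so across these four compounds, every exchange of one aromatic group for another at this place stays within the scatter. No measurement shown here bears on why these numbers stay so close.

From the compounds shown here alone, all four compounds carry an aromatic group at this place, so the effect of a non-aromatic group, such as a longer saturated chain, an amine or a carboxylic acid, remains open. Going by these compounds, it is also open whether any group here can move the number beyond the scatter.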